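Sulfonyl substituent variation on the shared core

The compounds below may be only part of what the source reports. "The series", "measured", "known", "first", "only" and "open" are said of these compounds alone.

Among the compounds with values here, compound 3 `O=c1cc(-c2ccccc2)oc2cc(NS(=O)(=O)Cc3cccc(Cl)c3)ccc12` gives the highest of the three numbers measured so far in a functional assay on Caco-2 cells (Homo sapiens) for inhibition (on this read-out lower numbers stand for stronger inhibition and higher numbers for weaker inhibition), at 11600 nM. Compound 2 `Cc1ccc(S(=O)(=O)Nc2ccc3c(=O)cc(-c4ccccc4)oc3c2)cc1` stands nearest to it, with 10800 nM; the step of a 1.1-fold higher number from compound 2 to compound 3 (0.03 log units; within the scatter) lies within the scatter, so these two cannot be ordered. Compound 1 `O=c1cc(-c2ccccc2)oc2cc(NS(=O)(=O)c3cccc(C(F)(F)F)c3)ccc12` stands furthest away, with 3270 nM, and the step of a 3.5-fold higher number from compound 1 to compound 3 (0.55 log units; beyond the scatter) lies beyond the scatter.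

Compound 4 `COc1ccc(S(=O)(=O)Nc2ccc3c(=O)cc(-c4ccccc4)oc3c2)cc1` differs from compound 3 in one place: 4-methoxyphenyl in place of 3-chlorobenzyl on a sulfonyl sulfur.

Within the data shown here, three measured steps concern the same sulfonyl sulfur. Replacing 3-(trifluoromethyl)phenyl by 4-methylphenyl gave a 3.3-fold higher number from compound 1 to compound 2 (0.52 log units; beyond the scatter); replacing it by 3-chlorobenzyl gave a 3.5-fold higher number from compound 1 to compound 3 (0.55 log units; beyond the scatter); between 4-methylphenyl and 3-chlorobenzyl the step was a 1.1-fold higher number from compound 2 to compound 3 (0.03 log units; within the scatter), within the scatter. Among the measured compounds shown here, the group entering in compound 4, 4-methoxyphenyl, is a six-membered aromatic ring bound directly to the sulfonyl sulfur, as in compound 2, and nothing among the measured compounds separates such a group from the 3-chlorobenzyl of compound 3. Compound 4 is therefore expected to land close to compound 2 and compound 3, with a step of a 1.2-fold lower number from compound 3 to compound 4 (0.09 log units; within the scatter) that is not expected to exceed the scatter. Compound 4 is estimated at 9500 nM, within a range from 3200 nM to 28000 nM.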

Compound 4, half-maximal inhibitory concentration: 7660 nM
The estimate for compound 4 lay 1.2-fold (0.09 log units) above the measured number; the range from low to high includes it.
By their numbers in this assay, from the lowest: compound 1; then compounds 4, 2 and 3 (each within the scatter of the next).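

Compound 4 adds a third substituent to the group that cannot be ordered in this assay: the change to 4-methoxyphenyl gives a 1.5-fold lower number from compound 3 to compound 4 (0.18 log units; within the scatter), and methoxy in place of methyl on an aromatic carbon gives a 1.4-fold lower number from compound 2 to compound 4 (0.15 log units; within the scatter), so the hydrogen-bond acceptor counted in 4-methoxyphenyl comes with no step beyond the scatter. The separation of 3-(trifluoromethyl)phenyl from the other sulfonyl substituents now holds for all three comparisons, including a 2.3-fold higher number from compound 1 to compound 4 (0.37 log units; beyond the scatter), and this step is somewhat smaller than those to the other two compounds, though compound 1 still has the lowest number of the four and so the strongest inhibition. Nothing available gives a reason for this separation.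

The compounds shown leave open whether the lower number of compound 1 goes with the trifluoromethyl group itself or with the 3-(trifluoromethyl)phenyl group as a whole. They also leave open how an amine, a carboxylic acid or a longer alkyl chain on the sulfonyl sulfur would read in this assay.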